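A few compounds are considered here, and "the series" means these few. Any claim that something is new, unique, unknown or untested is made for them only; others in the source may bear on it.

Of the compounds shown here, three built on one shared core have been measured in a functional assay on Vas deferens for antagonist activity at Alpha-1A adrenergic receptor (Rattus norvegicus); a higher number here means a more potent compound, by a factor of ten per unit of this negative logarithm, a lower number a less potent compound. Compound 1 `COc1cccc(OC)c1OCCNCCOc1ccccc1OCc1ccccc1Cl` gives 8.56, compound 2 `COc1cccc(OC)c1OCCNCCOc1ccccc1OCc1ccccc1C` gives 7.81, and compound 3 `COc1cccc(OC)c1OCCNCCOc1ccccc1OCc1cccc(C)c1` gives 8.3. Compound 3 therefore stands second highest of the three: the step of a number 0.26 log units lower from compound 1 to compound 3 (within the scatter) leaves it indistinguishable from compound 1, while the step of a number 0.49 log units higher from compound 2 to compound 3 (beyond the scatter) sets it clearly apart from compound 2.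

Compound 4 `COc1ccccc1COc1ccccc1OCCNCCOc1c(OC)cccc1OC` has not yet been measured. It differs from compound 3 in one place: 2-methoxyphenyl in place of 3-methylphenyl on a saturated chain carbon bound to an oxygen on an aromatic ring. Among the measured compounds shown here, two measured steps bear on this, since both alter the same ring. The step of a number 0.75 log units lower from compound 1 to compound 2 (beyond the scatter) came from methyl in place of chloro on an aromatic carbon, and the step of a number 0.49 log units higher from compound 2 to compound 3 (beyond the scatter) came from 3-methylphenyl in place of 2-methylphenyl. Changes on this ring thus shift potency by modest amounts in either direction, and a methoxy on it has no precedent here. A small downward step or none beyond the scatter, a number 0.30 log units lower from compound 3 to compound 4 (within the scatter), is therefore expected. For compound 4 in this assay the estimate is 8, within a range from 7.4 to 8.7.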

Compound 4, negative logarithm of the antagonist equilibrium constant: 8.53
Estimate against measurement, compound 4: 0.53 log units below; the range from low to high includes it.
By their numbers in this assay, from the lowest: compound 2; then compounds 3, 4 and 1 (each within the scatter of the next).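

With the 2-methoxyphenyl group in place, the step of a number 0.03 log units lower from compound 1 to compound 4 (within the scatter) and the step of a number 0.23 log units higher from compound 3 to compound 4 (within the scatter) show that compound 4 cannot be told apart from compound 1 or compound 3 in this assay, so this ring carries a methoxy with no loss that can be resolved. The only clear difference comes from the step of a number 0.72 log units higher from compound 2 to compound 4 (beyond the scatter), which groups methoxy with chloro and leaves compound 2, beyond the scatter from all three others, as the least potent of the four. Among these compounds, the low number belongs to the 2-methylphenyl group alone and not to every group in that place, but no measurement shown explains why.

The compounds shown leave open whether a 2-fluorophenyl, 2-hydroxyphenyl or 2-aminophenyl group would stay level with compound 1 and compound 4 or fall toward compound 2. They also leave open whether a 3-methoxyphenyl group would match the 3-methylphenyl group of compound 3, which would show whether methoxy and methyl differ in that other ring placement as they do in the 2-substituted pair.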